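A few compounds are considered here, and "the series" means these few. Any claim that something is new, unique, unknown or untested is made for them only; others in the source may bear on it.

Three compounds sharing one core were tested in a functional assay on Ehrlich cells (Mus musculus) for antiproliferative activity, read by trypan blue exclusion, with a stated time of 2 h, tested at 100 ug/mL; a higher number here means a stronger effect of the compound at the concentration tested, a lower number a weaker effect. Compound 1 `Cc1ccc(C2C(C#N)=C(N)N(c3ccc(S(N)(=O)=O)cc3)C3=C2C(=O)CCC3)cc1` gives 100%, compound 2 `N#CC1=C(N)N(c2ccc(S(N)(=O)=O)cc2)C2=C(C(=O)CCC2)C1/C=C/c1ccccc1` gives 45%, and compound 3 `COc1ccc2ccccc2c1C1C(C#N)=C(N)N(c2ccc(S(N)(=O)=O)cc2)C2=C1C(=O)CCC2` gives 80%, the second highest of the three numbers. All three differ only in the group on a saturated ring carbon, so the steps of a number 20 percentage points lower from compound 1 to compound 3 (beyond the scatter) and a number 35 percentage points higher from compound 2 to compound 3 (beyond the scatter) bear on the present change and show that exchanging this group can move the read-out strongly in either direction. Compound 4 `Cc1ccoc1C1C(C#N)=C(N)N(c2ccc(S(N)(=O)=O)cc2)C2=C1C(=O)CCC2` carries the change (3-methylfuran-2-yl in place of 2-methoxynaphthalen-1-yl on a saturated ring carbon). Going by the values given here, no measured step involves a five-membered aromatic ring at this place, so the direction is uncertain; a modest downward move is expected, a number 10 percentage points lower from compound 3 to compound 4 (within the scatter). Compound 4 is expected to give 70%, estimated between 40% and 100% in this assay.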

Compound 4, a percentage reported as activity, at one concentration (the size of the read-out at that concentration, not a potency): 45%
Compound 4: middle estimate off by 25 percentage points, on the high side; the measured number falls inside the stated range.
By their numbers in this assay, from the lowest: compounds 2 and 4 (each within the scatter of the next); then compound 3; then compound 1.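

In this assay, the first five-membered aromatic ring at this saturated ring carbon falls well short of both six-membered aromatic groups (a number 35 percentage points lower from compound 3 to compound 4 (beyond the scatter); a number 55 percentage points lower from compound 1 to compound 4 (beyond the scatter)). It reads the same as 2-phenylethenyl (no change at the digits printed from compound 2 to compound 4 (within the scatter)), so an aromatic ring here does not by itself secure a high number. No measured evidence explains these steps.

The compounds shown leave open whether the methyl on the furan contributes to this read-out, as an unsubstituted furan-2-yl would test. As far as these compounds go, how a butyl chain or a phenyl ring carrying an amine would read out at this carbon also remains open.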